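A few compounds are considered here, and "the series" means these few. Any claim that something is new, unique, unknown or untested is made for them only; others in the source may bear on it.

Measured so far:
- compound 1, `NC/C=C/CN(C[C@H]1Cc2ncccc2CN1)[C@H]1CCCc2cccnc21`: 37%
- compound 2, `NC(=O)NC/C=C\CN(C[C@H]1Cc2ncccc2CN1)[C@H]1CCCc2cccnc21`: 10%

Going by the values given here, in an ADME assay on microsomes from liver (Mus musculus) for metabolic stability, using NADPH, with a stated time of 10 min (a lower number here means that less of the compound is left, a higher number that more of the compound is left), compound 2 stands lowest of the two numbers; the only measured step is a number 27 percentage points lower from compound 1 to compound 2 (beyond the scatter), which swapped an aminomethyl group for a urea group. Compound 3, `NC(=O)NC/C=C/CN(C[C@H]1Cc2ncccc2CN1)[C@H]1CCCc2cccnc21`, keeps that urea and changes only the shape of the chain: the two compounds have the same atoms and bonds and differ only in configuration as drawn: 1 of 3 stereo elements differ; a double bond is drawn Z in compound 2 and E in compound 3. Among the compounds with values here, no measured step isolates this kind of change, so there is no direct guide; the step is expected to be small, within the scatter. Compound 3 is therefore expected to give 15%, between 5% and 35%. For compound 3 this means an expected step of a number 5 percentage points higher from compound 2 to compound 3 (within the scatter).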

Compound 3, percent of the compound remaining: 19%
Compound 3: middle estimate off by 4 percentage points, on the low side; the measured number falls inside the stated range.
By their numbers in this assay, from the lowest: compounds 2 and 3 (each within the scatter of the next); then compound 1.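

With the urea kept, the two double-bond geometries cannot be told apart in this assay (a number 9 percentage points higher from compound 2 to compound 3 (within the scatter)). This comparison speaks to the double bond alone because of one fact: the fact that compounds 2 and 3 differ only in the configuration as drawn. Compound 1 and compound 3 both carry the E double bond, so the carbamoyl group on the amine nitrogen can be read by itself, and its step lies beyond the scatter (a number 18 percentage points lower from compound 1 to compound 3 (beyond the scatter)).

Open, from the compounds shown here alone, is whether an acetyl or a methyl group on that amine nitrogen would give a number like that of carbamoyl. Also open, going by these compounds, is whether a saturated chain in place of the double bond would change the number.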